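Working notes: from 3-carbamoylbenzyl to 4-(methylsulfonyl)benzyl

The source may report more compounds than this note shows. Statements on the series, on what has been measured and on what is new or still open speak of the compounds shown alone.

In an ADME assay on MT4 cells (Homo sapiens) for cytotoxicity, read by MTT assay, with a stated time of 5 days (on this read-out lower numbers stand for higher toxicity in this test and higher numbers for lower toxicity in this test), compound 1 (`Cc1cc(C#N)cc(C)c1Oc1nc(NC2CCCN(Cc3ccc(C(N)=O)cc3)C2)nc2ccsc12`) gives 19500 nM, compound 2 (`Cc1cc(C#N)cc(C)c1Oc1nc(NC2CCC(NCc3ccc(C(N)=O)cc3)CC2)nc2ccsc12`) gives 7720 nM and compound 3 (`Cc1cc(C#N)cc(C)c1Oc1nc(NC2CCC(NCc3cccc(C(N)=O)c3)CC2)nc2ccsc12`) gives 9210 nM. Compound 3 therefore sits level with compound 2 within the scatter, while compound 1 shows the higher number, beyond the scatter of compound 3.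

Compound 4 (`Cc1cc(C#N)cc(C)c1Oc1nc(NC2CCC(NCc3ccc(S(C)(=O)=O)cc3)CC2)nc2ccsc12`) follows from compound 3 by one change: 4-(methylsulfonyl)phenyl in place of 3-carbamoylphenyl on a saturated chain carbon bound to an amine nitrogen. Among the measured compounds shown here, the only measured step on this group is a 1.2-fold higher number from compound 2 to compound 3 (0.08 log units; within the scatter), which moves the carbamoyl group and stays within the scatter. For the measured compounds named here, no measured step replaces the carbamoyl group with another group, so the evidence for this change is indirect and thin. On that basis, no shift beyond the scatter is expected in this assay. The expected size is a 1.1-fold lower number from compound 3 to compound 4 (0.03 log units; within the scatter). For compound 4 the estimated value is 8500 nM, with an expected range from 3500 nM to 20000 nM.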

Compound 4, half-maximal cytotoxic concentration: 75200 nM
Beside the measured number, compound 4's estimate is 8.8-fold (0.95 log units) below it, and the stated range ends below it.
By their numbers in this assay, from the lowest: compounds 2 and 3 (each within the scatter of the next); then compound 1; then compound 4.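

In this assay the group on this saturated chain carbon is now seen to matter: methylsulfonyl in place of carbamoyl on an aromatic carbon gives a 9.7-fold higher number from compound 2 to compound 4 (0.99 log units; beyond the scatter) (the cleanest comparison), and the change from 3-carbamoylphenyl to 4-(methylsulfonyl)phenyl gives an 8.2-fold higher number from compound 3 to compound 4 (0.91 log units; beyond the scatter) as well. Moving the carbamoyl group had stayed within the scatter, so the shift goes with the exchange of the group and not with where the carbamoyl group stood. Nothing available explains why this exchange raises the number.

On these data alone, whether the higher number belongs to methylsulfonyl itself, or would also appear with a carboxylic acid or a primary sulfonamide on the same aromatic carbon, stays open. Also open, as far as these compounds go, is whether 3-(methylsulfonyl)phenyl behaves like 4-(methylsulfonyl)phenyl, and whether the exchange carries over to the amine arrangement of compound 1.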